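Cytotoxicity notes: nitro for cyano on the benzyl ether

The compounds below may be only part of what the source reports. "The series", "measured", "known", "first", "only" and "open" are said of these compounds alone.

The series shares one core carrying a benzyl ether; compound 1 `O=c1c(OCc2cccc(Br)c2)c(-c2ccccc2)oc2cc(O)cc(O)c12` bears a 3-bromophenyl and compound 2 `N#Cc1ccc(COc2c(-c3ccccc3)oc3cc(O)cc(O)c3c2=O)cc1` a 4-cyanophenyl on the saturated chain carbon bound to the ring oxygen. In an ADME assay on Huh-5-2 cells (Homo sapiens) for cytotoxicity, read by WST assay, with a stated time of 3 days (on this read-out higher numbers stand for lower toxicity in this test and lower numbers for higher toxicity in this test), compound 1 gives 15000 nM, and compound 2 gives 48000 nM, the higher of the two numbers; the change 4-cyanophenyl in place of 3-bromophenyl gave a 3.2-fold higher number from compound 1 to compound 2 (0.51 log units; beyond the scatter). Compound 3 `O=c1c(OCc2ccc([N+](=O)[O-])cc2)c(-c2ccccc2)oc2cc(O)cc(O)c12` differs from compound 2 by nitro in place of cyano on an aromatic carbon, on an aromatic carbon para to a large group. Going by the values given here, no measured step exchanges one substituent of this kind for another at the same position; the only step known concerns a different group at a different site and is of modest size. For compound 3 the expected change is therefore a 1.2-fold lower number from compound 2 to compound 3 (0.08 log units; within the scatter), that is, none beyond the scatter. The estimate for compound 3 in this assay is 40000 nM, within 15000 nM to 100000 nM.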

Compound 3, half-maximal cytotoxic concentration: 40000 nM
Beside the measured number, compound 3's estimate shows no gap at the digits printed; low and high end bracket the measured number.
By their numbers in this assay, from the lowest: compound 1; then compounds 3 and 2 (each within the scatter of the next).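

In this assay, nitro in place of cyano on an aromatic carbon para to a large group gives a 1.2-fold lower number from compound 2 to compound 3 (0.08 log units; within the scatter), so this first exchange of one such substituent for another at the same position does not separate the two compounds. The 4-nitrophenyl also gives a 2.7-fold higher number from compound 1 to compound 3 (0.43 log units; beyond the scatter), which places it on the same side of compound 1 as the 4-cyanophenyl in a 3.2-fold higher number from compound 1 to compound 2 (0.51 log units; beyond the scatter). Nothing on hand offers an explanation for these numbers.

The steps from compound 1 change both the group and its place on the ring, so these two changes cannot be told apart here. An amine or a carboxylic acid on the same aromatic carbon would test whether the level of compounds 2 and 3 extends to groups of another kind.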